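From 4-hydroxyphenyl to phenyl: working notes on the series

This account rests on a few compounds, and the source may have more. Where it says the series, first, only, none or still open, it means among the compounds named here.

In a functional assay on HCT-116 cells (Homo sapiens) for inhibition, read by colorimetric assay, with a stated time of 3 days (a lower number here means a stronger inhibitor, a higher number a weaker inhibitor), compound 1 `COc1ccc(-c2cnc(NC(=O)CCCCCCNC(=O)C(O)(O)C(F)(F)F)s2)cc1` gives 930 nM and compound 2 `O=C(CCCCCCNC(=O)C(O)(O)C(F)(F)F)Nc1ncc(-c2ccc(Br)cc2)s1` gives 2460 nM while compound 3 `O=C(CCCCCCNC(=O)C(O)(O)C(F)(F)F)Nc1ncc(-c2ccc(O)cc2)s1` gives 1020 nM on the same read-out. Compound 3 stands within the scatter of compound 1 and clear of compound 2, which has the highest number of the three.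

Compound 4 `O=C(CCCCCCNC(=O)C(O)(O)C(F)(F)F)Nc1ncc(-c2ccccc2)s1` differs from compound 3 by a single change hydrogen in place of hydroxy on an aromatic carbon with hydrogen in place of hydroxy on an aromatic carbon, para to a large group. Among the compounds with values here, no measured step puts hydrogen on that carbon, so the evidence is indirect. The step of a 2.4-fold lower number from compound 2 to compound 3 (0.38 log units; beyond the scatter) for hydroxy in place of bromo and the step of a 2.6-fold higher number from compound 1 to compound 2 (0.42 log units; beyond the scatter) for bromo in place of methoxy are both modest. The step of a 1.1-fold higher number from compound 1 to compound 3 (0.04 log units; within the scatter) for hydrogen in place of methyl on the oxygen stays within the scatter.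

The three groups compared there span only a modest range in this assay and no large step is expected. The expected step is a 1.3-fold higher number from compound 3 to compound 4 (0.11 log units; within the scatter) and any shift would more likely be toward a higher number. For compound 4 the estimated value is 1300 nM with an expected range of 600 nM to 2800 nM as the working figure.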

Compound 4, half-maximal inhibitory concentration: 2660 nM
Compound 4: the middle estimate sits 2.0-fold (0.31 log units) below what was measured; measured number inside the range.
By their numbers in this assay, from the lowest: compounds 1 and 3 (each within the scatter of the next); then compounds 2 and 4 (each within the scatter of the next).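

Taking the hydroxy group off gives a 2.6-fold higher number from compound 3 to compound 4 (0.42 log units; beyond the scatter) in this assay and shows what this carbon, para to a large group, does with no substituent at all. The step of a 2.9-fold higher number from compound 1 to compound 4 (0.46 log units; beyond the scatter) points the same way, whereas a 1.1-fold higher number from compound 2 to compound 4 (0.03 log units; within the scatter) leaves bromo and hydrogen inseparable. Across these four compounds, hydroxy and methoxy therefore form a pair with the lower numbers, and bromo and hydrogen form a pair with the higher numbers, with no compound going against this split.

As far as these compounds go, it remains open whether an amine or a carboxylic acid on this carbon would join the hydroxy and methoxy pair, and whether a longer chain on the oxygen would keep the number seen for compound 1. Nothing available here explains why the four groups divide this way.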